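The source may hold more compounds than are shown below. What is called first, only, known or untested is meant among the compounds shown, and "the series" means these compounds.

Among the measured compounds shown here, compound 2 `O=C1/C(=C/c2ccc(Br)cc2)CCc2ccccc21` stands highest of the two numbers measured so far in a functional assay on L1210 cells (Mus musculus) for inhibition (on this read-out lower numbers stand for stronger inhibition and higher numbers for weaker inhibition), where compound 2 gives 202000 nM. Its nearest neighbour is compound 1 `O=C1/C(=C/c2ccccc2)CCc2ccccc21`, which in this assay gives 121000 nM; the step of a 1.7-fold higher number from compound 1 to compound 2 (0.22 log units; within the scatter) stays within the usual scatter, so the two compounds cannot be told apart on this read-out.

The next compound, compound 3 `Cc1ccc(/C=C2\CCc3ccccc3C2=O)cc1`, differs from compound 2 in one place: methyl in place of bromo on an aromatic carbon. For the measured compounds named here, the only measured step that bears on this position is the one from compound 1 to compound 2, in which a bromo group was added to the aromatic ring of compound 1, and that step, a 1.7-fold higher number from compound 1 to compound 2 (0.22 log units; within the scatter), was within the scatter. Going by the values given here, no measured step shows what methyl in place of bromo does on this scaffold, so the substitution of one small group by another at the same aromatic carbon is expected to change little. The step of a 1.3-fold lower number from compound 2 to compound 3 (0.13 log units; within the scatter) is therefore expected to fall within the scatter as well. Compound 3 is estimated at 150000 nM, with a likely range from 70000 nM to 320000 nM.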

Compound 3, half-maximal inhibitory concentration: 161000 nM
The estimate for compound 3 lay 1.1-fold (0.03 log units) below the measured number, and the stated range covers the measured number.
By their numbers in this assay, from the lowest: compounds 1, 3 and 2 (each within the scatter of the next).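

In this assay, the position on the aromatic ring para to a large group has now carried three different substituents, and none of them separates from the others. Methyl in place of bromo gives a 1.3-fold lower number from compound 2 to compound 3 (0.10 log units; within the scatter), and methyl in place of hydrogen gives a 1.3-fold higher number from compound 1 to compound 3 (0.12 log units; within the scatter), so neither comparison can be told apart from repeat-measurement noise, just as with the earlier bromo step. The earlier compounds showed this only for a halogen, whereas compound 3 extends the same reading to a small carbon group, and no measurement offered here explains why these three compounds cannot be told apart.

As far as these compounds go, what remains open is whether any group at this position can move the number beyond the scatter, for instance an amine, a carboxylic acid, or a longer chain such as hexyl. The compounds shown also say nothing about substituents on other carbons of this ring or about changes to the rest of the shared core.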